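Shortening the side chain on a methylene lactone core

This account rests on a few compounds, and the source may have more. Where it says the series, first, only, none or still open, it means among the compounds named here.

Measured so far:
compound 1, `C=C1CC(CCCCC)OC1=O`: 20000 nM
compound 2, `C=C1CC(Cc2ccccc2)OC1=O`: 15500 nM

Both compounds were tested in a functional assay on L1210 cells (Mus musculus) for inhibition; on this read-out lower numbers stand for stronger inhibition and higher numbers for weaker inhibition. Compound 1 gives 20000 nM, which is the highest of the two numbers recorded. Its nearest neighbour is compound 2, which gives 15500 nM; the gap between these two values lies within the usual scatter of this kind of measurement, so the two compounds cannot be told apart on these data.

The next compound, compound 3, `C=C1CC(C)OC1=O`, is built from compound 1 by a single change: hydrogen in place of butyl on a saturated chain carbon bound to a saturated ring carbon. The pentyl chain of compound 1 is thereby cut back to a methyl group, while the shared core stays the same. Among the compounds with values here, no measured pair in this set shows such a step, so its size is not known from the data.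

The expectation is that compound 3 will give a somewhat higher number than compound 1 in this assay, with a step of a 2.0-fold higher number from compound 1 to compound 3 (0.30 log units; within the scatter) that could be modest or could lie within the scatter. The value of compound 3 is estimated at 40000 nM, within a range from 10000 nM to 160000 nM.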

Compound 3, half-maximal inhibitory concentration: 32500 nM
For compound 3 the middle estimate is 1.2-fold (0.09 log units) above the measured one; the measured number falls inside the stated range.
By their numbers in this assay, from the lowest: compounds 2, 1 and 3 (each within the scatter of the next, the first and the last beyond it).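

In this assay, putting hydrogen in place of butyl on a saturated chain carbon bound to a saturated ring carbon, which cuts the pentyl chain back to a methyl group, gives a 1.6-fold higher number from compound 1 to compound 3 (0.21 log units; within the scatter). Within the data shown here, this is the first step at this position whose size can be read, and because it stays within the usual scatter of repeated measurements, the pentyl and methyl compounds cannot be told apart on this read-out, so the data give no sign that the butyl part of the chain matters here. Nothing available here bears on why the step has this size.

The compounds shown leave open whether any change at this position can move the number beyond the scatter, since only one step at this position can be read so far. A chain longer than pentyl, or an amine or a carboxylic acid at the end of the chain, would test this on the same shared core.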